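Dropping the trifluoromethyl group from compound 3

The source may report more compounds than this note shows. Statements on the series, on what has been measured and on what is new or still open speak of the compounds shown alone.

Compound 1 `COc1ccccc1C#Cc1cc(Cl)ccc1OCC(=O)O`: 190 nM
Compound 2 `CN(C)C(=O)c1ccc(C#Cc2cc(Cl)ccc2OCC(=O)O)cc1`: 55 nM
Compound 3 `O=C(O)COc1ccc(Cl)cc1C#Cc1ccccc1C(F)(F)F`: 24 nM

Of the compounds shown here, three sharing one core have been tested in an assay on CHO cells for displacement of a labelled ligand from prostaglandin D2 receptor 2 (Homo sapiens), read by scintillation counting; on this read-out lower numbers stand for stronger inhibition and higher numbers for weaker inhibition. Compound 3 gives the lowest number of the three; compound 2 sits nearest, and compound 1 is furthest away. Among the compounds with values here, the one step measured between compounds that differ in a single place is a 7.9-fold lower number from compound 1 to compound 3 (0.90 log units; beyond the scatter), a modest gain in favour of the trifluoromethyl group.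

Compound 4 `O=C(O)COc1ccc(Cl)cc1C#Cc1ccccc1` takes the opposite route: hydrogen in place of trifluoromethyl on an aromatic carbon, on an aromatic carbon of a six-membered aromatic ring of carbon only, ortho to a large group. Within the data shown here, only the step from compound 1 to compound 3 bears on this change, and it shows that what occupies this position matters to the reading in this assay. As far as these compounds go, a hydrogen there is untested, so the expectation rests on that single step. For compound 4 a weaker result than compound 3 is expected, a 5.0-fold higher number from compound 3 to compound 4 (0.70 log units; beyond the scatter), giving an estimated 120 nM with a range from 40 nM to 400 nM.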

Compound 4, inhibition constant: 108 nM
Estimate against measurement, compound 4: 1.1-fold (0.05 log units) above, and the stated range covers the measured number.
By their numbers in this assay, from the lowest: compound 3; then compounds 2, 4 and 1 (each within the scatter of the next, the first and the last beyond it).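

With a plain hydrogen now in place, the trifluoromethyl group can be judged against an empty position rather than only against methoxy. Removing it gives a change beyond the scatter (a 4.5-fold higher number from compound 3 to compound 4 (0.65 log units; beyond the scatter)), so the low number of compound 3 depends on having trifluoromethyl at this carbon. The other two groups do not separate from hydrogen, as both steps lie within the scatter (a 1.8-fold lower number from compound 1 to compound 4 (0.25 log units; within the scatter)) (a 2.0-fold higher number from compound 2 to compound 4 (0.29 log units; within the scatter)), which leaves trifluoromethyl as the only one of the three substituents that stands apart from the unsubstituted compound.

Why trifluoromethyl stands apart cannot be told from these numbers, as no supporting measurement bears on the result. Also open, as far as these compounds go, is how a methyl group, a single fluorine atom or an amine on the same carbon would compare with trifluoromethyl and with hydrogen.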